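A few compounds are considered here, and "the series" means these few. Any claim that something is new, unique, unknown or untested is made for them only; others in the source may bear on it.

Measured in a functional assay on the whole organism (blood, strain Wistar-Okamoto) with Rattus norvegicus as the target, with a stated time of 5 days; a higher number here means that more compound is needed for the effect, a lower number that less compound is needed:
compound 1, `CC(C)(C)C/N=C(/NC#N)Nc1cccnc1`: 2.5 mg/kg
compound 2, `CCCCCCC/N=C(\NC#N)Nc1cccnc1`: > 50 mg/kg
compound 3, `CCC(C)/N=C(\NC#N)Nc1cccnc1`: 20 mg/kg.

For compound 2 the value given is a limit of the assay and not a number, namely (the limit of > 50 mg/kg in this assay, at which 1 of the 3 values shown sits). Compound 3 therefore holds the higher of the two numbers actually read, and compound 1 lies below it by a gap that is beyond the scatter. Among the compounds with values here, no step between measured compounds differing in a single place is defined here, so no measured step size is available for guidance.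

Compound 4, `CCC(C)(CC)/N=C(\NC#N)Nc1cccnc1`, differs from compound 3 by ethyl in place of hydrogen on a saturated chain carbon bound to a double-bonded nitrogen and two saturated chain carbons. The expected step in this assay is a 2.0-fold lower number from compound 3 to compound 4 (0.30 log units; within the scatter), a modest move toward a lower number, near the edge of the scatter. Compound 4 is estimated at 10 mg/kg, in the range 3 mg/kg to 40 mg/kg.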

Compound 4, minimum effective dose: 0.5 mg/kg
Compound 4: middle estimate off by 20-fold (1.30 log units), on the high side; measured number outside the range, below it.
By their numbers in this assay, from the lowest: compound 4; then compound 1; then compound 3. At a limit, above all of these: compound 2.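

Within the data shown here, at the saturated chain carbon bound to a double-bonded nitrogen and two saturated chain carbons, ethyl in place of hydrogen (sec-butyl to 1-ethyl-1-methylpropyl) gives a 40-fold lower number from compound 3 to compound 4 (1.60 log units; beyond the scatter) in this assay, the only single-place change that can be read. This position is therefore not neutral to substitution: replacing one hydrogen there moves the dose well beyond the scatter. Nothing measured here accounts for the size of this step.

As far as these compounds go, whether methyl or a longer chain such as propyl in place of that hydrogen moves the number as far remains open. So does the outcome with a hydroxyl group on the same carbon.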